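A Second Chloro on the Benzyloxy Ring

The source may hold more compounds than are shown below. What is called first, only, known or untested is meant among the compounds shown, and "the series" means these compounds.

Compound 3 `Cc1ccc(NC(=O)NC(=O)c2ccc(OCc3ccccc3Cl)cc2)cc1-c1nc2ccccc2[nH]1` gives 21500 nM in a functional assay on MNK45 cells (Homo sapiens) for inhibition, read by MTT assay, with a stated time of 48 h; a lower number here means a stronger inhibitor, a higher number a weaker inhibitor. Among the measured compounds shown here, of the three numbers so far, that of compound 3 is the second highest; compound 2 `Cc1ccc(NC(=O)NC(=O)c2ccc(OCc3ccc(C(F)(F)F)cc3)cc2)cc1-c1nc2ccccc2[nH]1` gives 16800 nM and compound 1 `Cc1ccc(NC(=O)NC(=O)c2ccc(OCc3ccccc3)cc2)cc1-c1nc2ccccc2[nH]1` gives 35100 nM, and both lie within the usual scatter of compound 3. Compound 4 `Cc1ccc(NC(=O)NC(=O)c2ccc(OCc3ccc(Cl)cc3Cl)cc2)cc1-c1nc2ccccc2[nH]1` differs from compound 3 by chloro in place of hydrogen on an aromatic carbon. For the measured compounds named here, two measured steps bear on this change, each of which adds one substituent to a ring that carries none in compound 1: a 2.1-fold lower number from compound 1 to compound 2 (0.32 log units; beyond the scatter) and a 1.6-fold lower number from compound 1 to compound 3 (0.21 log units; within the scatter). A modest downward step is therefore expected, a 1.5-fold lower number from compound 3 to compound 4 (0.19 log units; within the scatter). Compound 4 is estimated at 14000 nM, with a range from 6000 nM to 33000 nM.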

Compound 4, half-maximal inhibitory concentration: 2550 nM
Compound 4: middle estimate off by 5.5-fold (0.74 log units), on the high side; measured number outside the range, below it.
By their numbers in this assay, from the lowest: compound 4; then compounds 2, 3 and 1 (each within the scatter of the next, the first and the last beyond it).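

In this assay, a chloro placed para to a large group and meta to the first chloro gives an 8.4-fold lower number from compound 3 to compound 4 (0.93 log units; beyond the scatter) and so counts for much more on this ring than the earlier single substituents did. The same compound also stands apart through a 6.6-fold lower number from compound 2 to compound 4 (0.82 log units; beyond the scatter) and through a 14-fold lower number from compound 1 to compound 4 (1.14 log units; beyond the scatter) as the only ring here with two substituents. Nothing measured here explains the gain. Still open, going by these compounds, is whether the new chloro would do the same with the first chloro absent, and whether a methoxy, an amine or a carboxylic acid at this place would keep the gain.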